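The compounds below may be only part of what the source reports. "The series", "measured", "known", "first", "only" and "open" are said of these compounds alone.

Compound 1 `O=c1[nH]c(=O)n([C@H]2C[C@H](O)[C@@H](CO)O2)cc1-c1cn(-c2ccc(Br)cc2)nn1` and compound 2 `O=c1[nH]c(=O)n([C@H]2C[C@H](O)[C@@H](CO)O2)cc1-c1cn(-c2ccc(Oc3ccccc3)cc2)nn1` share one core and differ at a single point: phenoxy in place of bromo on an aromatic carbon. In an ADME assay on L1210 cells (Mus musculus) for cytotoxicity, read by cell counting, with a stated time of 2 days (a lower number here means a stronger inhibitor, a higher number a weaker inhibitor), compound 1 gives 4600 nM, and compound 2 gives 500 nM. The step of a 9.2-fold lower number from compound 1 to compound 2 (0.96 log units; beyond the scatter) is therefore a clear one, with the phenoxy compound giving the lower number.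

Compound 3 `O=c1[nH]c(=O)n([C@H]2C[C@H](O)[C@@H](CO)O2)cc1-c1cnnn1-c1ccc(Br)cc1` is built from the same atoms as compound 1, joined differently, and the difference between the two cores is not broken down here. In this assay compound 3 gives 61000 nM, the highest number among the three measured compounds, well apart from both compound 1 and compound 2.

Compound 4 `O=c1[nH]c(=O)n([C@H]2C[C@H](O)[C@@H](CO)O2)cc1-c1cnnn1-c1ccc(Oc2ccccc2)cc1` stands to compound 3 as compound 2 stands to compound 1: phenoxy in place of bromo on an aromatic carbon. Since the place of the change is described in the same words for both pairs, it is the same change made on the core of compound 3. Its outcome in this assay is not yet known.

The expected step is an 8.7-fold lower number from compound 3 to compound 4 (0.94 log units; beyond the scatter), an estimate that rests on the measured step of a 9.2-fold lower number from compound 1 to compound 2 (0.96 log units; beyond the scatter), carried over to the other core. Because compound 3 gives 61000 nM, compound 4 is estimated to give 7000 nM in this assay, with a likely span from 2500 nM to 20000 nM to allow for the core behaving differently.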

Compound 4, half-maximal inhibitory concentration: 134000 nM
For compound 4 the middle estimate is 19-fold (1.28 log units) below the measured one, outside the stated range (above it).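

In this assay the change from bromo to phenoxy on an aromatic carbon does not carry over between the two cores: it gives a 2.2-fold higher number from compound 3 to compound 4 (0.34 log units; beyond the scatter), so the number rises on the core of compound 3 where it fell on the core of compound 1, and the two steps are clearly different: the same change on two cores in this assay, a 9.2-fold lower number (0.96 log units; beyond the scatter) from compound 1 to compound 2 and a 2.2-fold higher number (0.34 log units; beyond the scatter) from compound 3 to compound 4, 20-fold (1.31 log units) apart, beyond the scatter of two such steps. In these two matched pairs, therefore, the step measured on one core is no reliable guide to the step on the other, in size or in direction. This rests on a single change made on two cores, however, so it shows that the outcome of this change depends on the core in these compounds, but it does not show why, nor does it show that any other change would fail to carry over in the same way.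

The compounds shown carry only bromo or phenoxy at this place on the ring, so it remains open whether a methoxy group, a fluoro group, an amine or a carboxylic acid would also give steps that differ between the two cores. From the compounds shown here alone, it is likewise open whether a benzyloxy group, with its longer link to the second ring, would follow compound 2 or compound 4.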